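The source may report more compounds than this note shows. Statements on the series, on what has been measured and on what is new or still open speak of the compounds shown alone.

In a functional assay on HCT-116 cells (Homo sapiens) for cytotoxicity, read by hypoxanthine incorporation, with a stated time of 72 h, tested at 10 uM (a lower number here means less inhibition of growth, a higher number more inhibition of growth at the concentration tested), compound 2 `CC(C)C[C@@H]1NC(=O)[C@H](Cc2ccccc2)NC(=O)[C@@H](Cc2ccccc2)NC(=O)[C@@H](CCCCNC(=O)OCc2ccc(Cl)cc2)NC(=O)[C@H](C(C)C)N(C)C1=O` stands highest of three, with 69% measured. Compound 3 `CC(C)C[C@@H]1NC(=O)[C@H](Cc2ccccc2)NC(=O)[C@@H](Cc2ccccc2)NC(=O)[C@H](CCCCNC(=O)OCc2ccc(Cl)cc2)NC(=O)[C@H](C(C)C)N(C)C1=O` gives 58% there and compound 1 `CC(C)C[C@@H]1NC(=O)[C@H](CCCN)NC(=O)[C@H](C(C)C)NC(=O)[C@H](CC(C)C)NC(=O)[C@@H](Cc2ccc(O)cc2)NC1=O` gives 0% there. Compound 4 `CC(C)C[C@@H]1NC(=O)[C@H](Cc2ccccc2)NC(=O)[C@@H](Cc2ccccc2)NC(=O)[C@@H](CCCCNC(=O)OCc2ccccc2)NC(=O)[C@H](C(C)C)N(C)C1=O` differs from compound 2 by hydrogen in place of chloro on an aromatic carbon and so carries hydrogen in place of chloro on an aromatic carbon, 4-chlorobenzyl becoming benzyl. Among the measured compounds shown here, the one measured step is a number 11 percentage points lower from compound 2 to compound 3 (beyond the scatter) and it concerns configuration alone (the fact that compounds 2 and 3 differ only in the configuration as drawn), so it offers only a rough size for a single change and does not test this one. A modest drop of similar size is expected in this assay, with the direction untested. The expectation is a number 11 percentage points lower from compound 2 to compound 4 (beyond the scatter) as the estimated step. Estimated for compound 4 is 58% with 38% to 78% as the expected range.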

Compound 4, percent growth inhibition at one concentration: 36%
For compound 4 the middle estimate is 22 percentage points above the measured one; measured number outside the range, below it.
By their numbers in this assay, from the lowest: compound 1; then compound 4; then compound 3; then compound 2.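

In this assay, the chloro on the aromatic carbon matters: a number 33 percentage points lower from compound 2 to compound 4 (beyond the scatter). This step on going from 4-chlorobenzyl to benzyl is larger than the one seen for the configuration change, a number 11 percentage points lower from compound 2 to compound 3 (beyond the scatter), so a single atom at this position carries more of the growth inhibition than that stereocentre does. Nothing available accounts for the size of this step.

From the compounds shown here alone, how fluoro, methoxy or an amine at this position would compare stays open. So does whether the same change, made on compound 3, gives a step of similar size.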